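Benzyl amide to 4-methylphenyl amide on a shared core

The compounds below may be only part of what the source reports. "The series", "measured", "known", "first", "only" and "open" are said of these compounds alone.

Compound 1, `O=C(NCc1ccccc1)c1csc(-c2c[nH]c3ccccc23)n1`, gives 74500 nM in an ADME assay on HEK-293T cells (Homo sapiens) for cytotoxicity, read by MTT assay, with a stated time of 48 h, in the presence of a further agent that is not named here; on this read-out higher numbers stand for weaker inhibition and lower numbers for stronger inhibition.
Compound 2, `COc1ccc(NC(=O)c2csc(-c3cn(Cc4ccc(Cl)cc4)c4ccccc34)n2)cc1`, reaches only a limit in this assay, namely > 100000 nM.
Compound 3, `COc1ccc2[nH]cc(-c3nc(C(=O)Nc4cc(OC)c(OC)c(OC)c4)cs3)c2c1`, gives 8740 nM in this assay.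

Among the compounds that give a number, compound 1 holds the highest one; compound 3 lies lower, and that gap is beyond the usual scatter. Compound 4, `Cc1ccc(NC(=O)c2csc(-c3c[nH]c4ccccc34)n2)cc1`, is the compound to be measured. It differs from compound 1 in one place: 4-methylphenyl in place of benzyl on an amide-type nitrogen. Among the compounds with values here, no measured pair differs in exactly this way, so no measured step shows what it does. Compounds 2 and 3 both carry an aryl group on the amide nitrogen, but each also differs from compound 1 elsewhere, so their values say nothing firm about this change on its own. The step from compound 1 to compound 4 is therefore expected to be modest, as a 1.5-fold lower number from compound 1 to compound 4 (0.17 log units; within the scatter), and likely within the scatter. Compound 4 is estimated at 50000 nM, with a range from 12000 nM to 150000 nM.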

Compound 4, half-maximal inhibitory concentration: > 100000 nM
Compound 4: only a limit was reported; the forecaster's own chance of this, stated with the estimate: 30%; middle value at least 2.0-fold (0.30 log units) away from the limit.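

In this assay compound 4 reaches only a limit, > 100000 nM, so it has no exact number. Within the data shown here, this is the first direct view of 4-methylphenyl in place of benzyl on the amide nitrogen, and it gives an at least 1.3-fold higher number from compound 1 to compound 4 (0.12 log units; that floor lies within the scatter): the number does not fall with this change, but the smallest step it allows cannot be told apart from the scatter. The true size of the step stays hidden, and what can be read at this position is capped by a ceiling shared with another compound: the limit of > 100000 nM in this assay, at which 2 of the 4 values shown sit.

On these data alone, what an amine or a carboxylic acid in place of the methyl on the 4-methylphenyl group would do in this assay remains open. So does the effect of a longer chain in place of benzyl on the same nitrogen.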